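The compounds below may be only part of what the source reports. "The series", "measured", "known", "first", "only" and "open" are said of these compounds alone.

Measured so far in a functional assay on LAC cells (Homo sapiens) for cytotoxicity, read by MTT assay, with a stated time of 72 h; a lower number here means that less compound is needed, a higher number that more compound is needed for the effect:

Compound 1 `CCOC(=O)c1cn(C[C@H]2O[C@@H](n3ccc(=O)[nH]c3=O)[C@H](SCC)[C@@H]2SCC)nn1` — >= 100000 nM, which is a limit of the assay, not a number.
Compound 2 `CCS[C@@H]1[C@H](SCC)[C@@H](Cn2cc(-c3cccs3)nn2)O[C@H]1n1ccc(=O)[nH]c1=O` — 86500 nM.
Compound 3 `CCOC(=O)c1cn(C[C@H]2O[C@@H](n3cc(C)c(=O)[nH]c3=O)[C@H](SCC)[C@@H]2SCC)nn1` — >= 100000 nM, again a limit of the assay.

Two of the three values sit at the limit of >= 100000 nM in this assay, at which 2 of the 3 values shown sit, so only compound 2 has a read number. Within the data shown here, the one measured step that can be read, an at least 1.1-fold lower number from compound 1 to compound 2 (0.06 log units; that floor lies within the scatter), comes from the change (thiophen-2-yl in place of ethoxycarbonyl on an aromatic carbon); its floor lies within the scatter. The other measured pair gives a step that the two limits leave unreadable from compound 1 to compound 3 for the change (methyl in place of hydrogen on an aromatic carbon).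

Compound 4 `CCS[C@@H]1[C@H](SCC)[C@@H](Cn2cc(-c3cccs3)nn2)O[C@H]1n1cc(C)c(=O)[nH]c1=O` is not yet measured. It differs from compound 3 by thiophen-2-yl in place of ethoxycarbonyl on an aromatic carbon, the same change that separates compound 2 from compound 1, set on the same place word for word; the two cores differ by methyl in place of hydrogen on an aromatic carbon. Among the measured compounds shown here, since compound 3 stands at the limit, as compound 1 does, the earlier step of an at least 1.1-fold lower number from compound 1 to compound 2 (0.06 log units; that floor lies within the scatter) is the only guide. Compound 4 is expected to show an at least 1.1-fold lower number from compound 3 to compound 4 (0.04 log units; that floor lies within the scatter), landing close to the value of compound 2 or at the limit. The estimate for compound 4 in this assay is 90000 nM, with a range from 40000 nM to 160000 nM.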

Compound 4, half-maximal effective concentration: >= 100000 nM
Compound 4: only a limit was reported (the forecaster's own chance of this, stated with the estimate: 50%); middle value at least 1.1-fold (0.04 log units) from the limit.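

In this assay compound 4 gives >= 100000 nM as a limit and not a number, and the steps joining two limits cannot be read, so thiophen-2-yl in place of ethoxycarbonyl has no size on the core of compound 3 to set beside its step on the core of compound 1. Among these compounds, the one readable new step is an at least 1.1-fold higher number from compound 2 to compound 4 (0.06 log units; that floor lies within the scatter) for methyl in place of hydrogen on an aromatic carbon, and it neither shows nor excludes a difference between the two cores. Carrying the change from one core to the other is therefore neither confirmed nor ruled out, because nearly all of the series rests on a single limit: the limit of >= 100000 nM in this assay, at which 3 of the 4 values shown sit.

Open, as far as these compounds go, is how an aminomethyl group, a carboxylic acid or a longer chain would read in place of thiophen-2-yl in this assay on either core. Also open, from the compounds shown here alone, is whether the two changes would give comparable sizes on compounds with values clear of the limit.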